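Hydroxy to trifluoromethyl on the anilide, acetyl series

A few compounds are considered here, and "the series" means these few. Any claim that something is new, unique, unknown or untested is made for them only; others in the source may bear on it.

Of the compounds shown here, three of the shared core have been measured in a functional assay on PC-3 cells (Homo sapiens) for cytotoxicity, read by sulforhodamine B assay, with a stated time of 72 h; on this read-out higher numbers stand for weaker inhibition of growth and lower numbers for stronger inhibition of growth. Within the data shown here, compound 1 `O=C(Nc1ccccc1C(F)(F)F)C1CCc2ccccc2N1C(=O)c1ccccc1` gives 5560 nM, compound 2 `O=C(Nc1ccccc1C(F)(F)F)C1CCc2ccccc2N1C(=O)c1ccccc1Cl` gives 5140 nM, and the one measured step, a 1.1-fold lower number from compound 1 to compound 2 (0.03 log units; within the scatter), is within the scatter. Among the measured compounds shown here, compound 3 `CC(=O)N1c2ccccc2CCC1C(=O)Nc1ccccc1O` gives 70700 nM, the highest of the three numbers; no step is computed for it against compound 1 or compound 2, which differ from it in two places at once.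

Compound 4 `CC(=O)N1c2ccccc2CCC1C(=O)Nc1ccccc1C(F)(F)F` is the next compound. Its change from compound 3 is trifluoromethyl in place of hydroxy on an aromatic carbon, on an aromatic carbon of a six-membered aromatic ring of carbon only, ortho to a large group. For the measured compounds named here, no measured step covers this change: the only step on hand concerns the other acyl substituent and is flat. What the two sets of values show is that both trifluoromethyl anilides sit well below compound 3, so a lower number for compound 4 is expected, though with wide uncertainty since the acyl group also differs.

Compound 4 is expected at 15000 nM, with a range of 4000 nM to 55000 nM. The expected step is a 4.7-fold lower number from compound 3 to compound 4 (0.67 log units; beyond the scatter).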

Compound 4, concentration for 50% growth inhibition: > 80000 nM
Compound 4 was reported as a limit; the forecaster's own chance of this, stated with the estimate: 5%; at least 5.3-fold (0.72 log units) between middle value and limit.
By their numbers in this assay, from the lowest: compounds 2 and 1 (each within the scatter of the next); then compound 3. At a limit, above all of these: compound 4.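

In this assay compound 4 is reported as a limit and not a number: the limit of > 80000 nM in this assay, at which 1 of the 4 values shown sits. The step is an at least 1.1-fold higher number from compound 3 to compound 4 (0.05 log units; that floor lies within the scatter), so trifluoromethyl in place of hydroxy at this position brings no lower number with the acetyl group in place. With trifluoromethyl held constant, the acyl group carries the large difference: methyl in place of phenyl gives an at least 14-fold higher number from compound 1 to compound 4 (1.15 log units; beyond the scatter), and methyl in place of 2-chlorophenyl gives an at least 15-fold higher number from compound 2 to compound 4 (1.19 log units; beyond the scatter).

From the compounds shown here alone, how far the true value of compound 4 lies past the limit stays open, and with it the full size of these steps. Also open, going by these compounds, is whether hydroxy or an amine at this position would keep the number of compound 1, and whether a longer chain in place of the acetyl methyl would recover growth inhibition.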